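A few compounds are considered here, and "the series" means these few. Any claim that something is new, unique, unknown or untested is made for them only; others in the source may bear on it.

Series notes. Compound 1 `COc1ccc(C(=O)/C=C/c2cc(-c3cc(OC)c(OC)c(OC)c3)n[nH]2)cc1OC` in a functional assay on KM12 cells (Homo sapiens) for inhibition, read by sulforhodamine B assay, with a stated time of 48 h (a higher number here means a weaker inhibitor of growth, a lower number a stronger inhibitor of growth), gives 1070 nM, and compound 2 `COc1ccc(C(=O)/C=C/c2cc(-c3cc(OC)c(OC)c(OC)c3)n[nH]2)cc1` in this assay gives 1560 nM. Compound 1 holds the lower of the two numbers, with compound 2 nearest: a 1.5-fold higher number from compound 1 to compound 2 (0.16 log units; within the scatter). Compound 3 `COc1cc(C(=O)/C=C/c2cc(-c3cc(OC)c(OC)c(OC)c3)n[nH]2)cc(OC)c1OC` has not yet been measured in this assay. It differs from compound 1 by one change: methoxy in place of hydrogen on an aromatic carbon. Among the measured compounds shown here, the only measured step that bears on this is the one in which a methoxy leaves an aromatic carbon, a 1.5-fold higher number from compound 1 to compound 2 (0.16 log units; within the scatter), a step that stayed within the scatter; the present change is the opposite kind, a methoxy entering an aromatic carbon. With one such step in hand and no movement beyond the scatter, no step beyond the scatter is expected in this assay either. Compound 3 is therefore estimated at 950 nM, within the range 400 nM to 2300 nM. The expected step is a 1.1-fold lower number from compound 1 to compound 3 (0.05 log units; within the scatter).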

Compound 3, concentration for 50% growth inhibition: 1490 nM
The estimate for compound 3 lay 1.6-fold (0.20 log units) below the measured number; measured number inside the range.
By their numbers in this assay, from the lowest: compounds 1, 3 and 2 (each within the scatter of the next).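

Methoxy in place of hydrogen on this aromatic carbon, ortho to a methoxy group and meta to a large group, leaves the result in this assay within the scatter (a 1.4-fold higher number from compound 1 to compound 3 (0.14 log units; within the scatter)). Together with the earlier step in which a methoxy left this ring (a 1.5-fold higher number from compound 1 to compound 2 (0.16 log units; within the scatter)), this shows that, around compound 1, neither entry nor loss of one methoxy moves the number beyond the scatter. No measured evidence bears on the result, so no cause can be given.

Still open, from the compounds shown here alone, is whether a group other than methoxy on this carbon, such as a hydroxyl, an amine, a carboxylic acid or a longer chain like butoxy, would give a step beyond the scatter. The compounds shown also leave open what changes on the other methoxy-bearing ring would do, since all three share it unchanged.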